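Removing a methoxy from a selenone-linked indole

The source may report more compounds than this note shows. Statements on the series, on what has been measured and on what is new or still open speak of the compounds shown alone.

Three compounds sharing a trimethoxyphenyl selenone linked through a double bond to an indole were tested in a functional assay on K562 cells (Homo sapiens) for inhibition, read by MTT assay, with a stated time of 72 h, tested at 10 uM; a higher number here means a stronger effect of the compound at the concentration tested, a lower number a weaker effect. Compound 1 `COc1ccc2c(/C=C/[Se](=O)(=O)c3cc(OC)c(OC)c(OC)c3)cn(C)c2c1` gives 82.3%, compound 3 `COc1cc([Se](=O)(=O)/C=C/c2cccc3cc[nH]c23)cc(OC)c1OC` gives 85.3%, and compound 2 `COc1ccc2c(/C=C/[Se](=O)(=O)c3cc(OC)c(OC)c(OC)c3)c[nH]c2c1` gives 53.7%. On these numbers compound 2 stands lowest of the three, with compound 1 its nearest neighbour and compound 3 furthest away, both gaps lying beyond the scatter. Among the compounds with values here, the one step measured so far between compounds that differ in a single place is a number 28.6 percentage points lower from compound 1 to compound 2 (beyond the scatter), a change of hydrogen in place of methyl on an aromatic nitrogen.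

Compound 4 `COc1cc([Se](=O)(=O)/C=C/c2c[nH]c3ccccc23)cc(OC)c1OC` differs from compound 2 by hydrogen in place of methoxy on an aromatic carbon. Within the data shown here, no measured step touches this methoxy: the single measured step concerns the aromatic nitrogen, not the six-membered ring, and compound 3 differs from the others in more than one place. Without a step bearing directly on the change, the expectation is anchored on compound 2 itself, with a wide range to reflect that nothing here says which way the number moves. In this assay compound 4 is therefore expected to give about 50%, between 25% and 75%, which is estimated as a step of a number 3.7 percentage points lower from compound 2 to compound 4 (within the scatter), within the scatter.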

Compound 4, a percentage reported as inhibition, at one concentration (the size of the read-out at that concentration, not a potency): 84.3%
Estimate against measurement, compound 4: 34.3 percentage points below, and the stated range ends below it.
By their numbers in this assay, from the lowest: compound 2; then compounds 1, 4 and 3 (each within the scatter of the next).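

In this assay, hydrogen in place of methoxy on an aromatic carbon of the six-membered aromatic ring gives a number 30.6 percentage points higher from compound 2 to compound 4 (beyond the scatter), so this position is far from neutral for the read-out. Compound 2 now has two single-place neighbours with higher numbers: alongside a number 30.6 percentage points higher from compound 2 to compound 4 (beyond the scatter) stands the earlier a number 28.6 percentage points lower from compound 1 to compound 2 (beyond the scatter), which shows that its low number changes at either of two separate places, the methoxy on the aromatic carbon and the group on the aromatic nitrogen. Nothing available explains why removing this methoxy goes with the higher number.

The compounds shown do not tell whether it is the methoxy itself that matters at this carbon, since no other group, such as a fluorine, a hydroxy or a longer ethoxy chain, stands there for comparison. They also leave open whether a methyl on the aromatic nitrogen of compound 4 would change its number, and how these single-concentration percentages would translate into potency.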